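Swapping the aryl group on a thiosemicarbazone hydrazone

The source may hold more compounds than are shown below. What is called first, only, known or untested is meant among the compounds shown, and "the series" means these compounds.

The shared core is the thiosemicarbazide seen in compound 1 `CC1=CC[C@H](C(C)(C)NC(=S)NN)CC1`. In a functional assay on NCI-H460 cells (Homo sapiens) for inhibition, read by sulforhodamine B assay, with a stated time of 48 h (a higher number here means a weaker inhibitor of growth, a lower number a stronger inhibitor of growth), compound 1 gives only a limit, > 100000 nM. For the measured compounds named here, compound 2 `COc1ccc(/C=N/NC(=S)NC(C)(C)[C@H]2CC=C(C)CC2)cc1` carries a 4-methoxyphenyl on the hydrazone carbon, and in this assay compound 2 gives 47800 nM, the only number among the three measured compounds. Compound 3 `CC1=CC[C@H](C(C)(C)NC(=S)N/N=C/c2ccc(N(C)C)cc2)CC1` has a dimethylamino in place of the methoxy on an aromatic carbon; in this assay compound 3 gives only a limit, > 100000 nM. Going by the values given here, the step of an at least 2.0-fold higher number from compound 2 to compound 3 (0.32 log units; beyond the scatter) is the only measured change of the aryl substituent, and it weakens, as far as the limit of > 100000 nM in this assay, at which 2 of the 3 values shown sit, lets it be read. Compound 4 `CC1=CC[C@H](C(C)(C)NC(=S)N/N=C/c2ccccc2Cl)CC1` differs from compound 2 by 2-chlorophenyl in place of 4-methoxyphenyl on a carbon with a double bond to nitrogen. Among the compounds with values here, no measured step shows this change directly; the one aryl change seen moved compound 3 weaker, and two of three values rest at the limit. Compound 4 is therefore expected to be similar to or weaker than compound 2, a step of a 1.5-fold higher number from compound 2 to compound 4 (0.17 log units; within the scatter), giving an estimated 70000 nM, within 25000 nM to 200000 nM.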

Compound 4, concentration for total growth inhibition: 81000 nM
Beside the measured number, compound 4's estimate is 1.2-fold (0.06 log units) below it, and the stated range covers the measured number.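

In this assay, putting 2-chlorophenyl in place of 4-methoxyphenyl on the carbon with a double bond to nitrogen gives a 1.7-fold higher number from compound 2 to compound 4 (0.23 log units; within the scatter), so the two compounds cannot be told apart. The methoxy group is therefore not needed for a number to be read at this place, whereas the dimethylamino change left only a limit. Even so, the numbers shown all remain crowded at the weak end of the scale: the limit of > 100000 nM in this assay, at which 2 of the 4 values shown sit.

The change to compound 4 replaces the substituent and moves it in a single step, so the compounds shown cannot separate the effect of the chlorine from that of where it sits. On these data alone, it also remains open whether an aryl group carrying a nitro group or a carboxylic acid, or a pyridine ring, would give a clearly lower number.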